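A few compounds are considered here, and "the series" means these few. Any claim that something is new, unique, unknown or untested is made for them only; others in the source may bear on it.

Compound 1 `CCn1cnc2ncnc(N)c21` gives > 100000 nM in an assay on CHO cells for displacement of a labelled ligand from adenosine receptor A1 (Homo sapiens); a lower number here means a stronger inhibitor, a higher number a weaker inhibitor.
Compound 2 `CCCn1cnc2ncnc(N)c21` gives > 100000 nM in this assay.
Compound 3 `CC(C)Cn1cnc2ncnc(N)c21` gives > 100000 nM in this assay.

Each of these three values is a limit of the assay, not a measured number; the binding was too weak to put a figure on. Compound 3 therefore stands at the same limit as the other two, as summed up in the limit of > 100000 nM in this assay, at which 3 of the 3 values shown sit. For that reason none of the steps between the measured compounds can be read: a step that the two limits leave unreadable from compound 1 to compound 2, a step that the two limits leave unreadable from compound 1 to compound 3 and a step that the two limits leave unreadable from compound 2 to compound 3 all run from one limit to another, and their size is unknown.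

Compound 4 `Nc1ncnc2ncn(CCCO)c12` has not yet been measured. It differs from compound 3 in one place: 2-hydroxyethyl in place of isopropyl on a saturated chain carbon bound to an aromatic nitrogen. Among the compounds with values here, nothing among the measured steps gives a readable size for any change on this carbon, so there is no basis to expect a move away from the limit. The step from compound 3 to compound 4 is expected to be a number no higher from compound 3 to compound 4 (the limit leaves the size open), with no change beyond the scatter. Compound 4 is estimated at 100000 nM, in the range 30000 nM to 300000 nM, most likely reported again only as a limit.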

Compound 4, inhibition constant: > 100000 nM
Compound 4: a limit, no number; the forecaster's own chance of this, stated with the estimate: 80%; the middle value sits exactly at the limit.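

Compound 4 gives > 100000 nM in this assay, a limit and not a number. Its steps from compound 1, compound 2 and compound 3 therefore cannot be read, as all four sit at one limit: the limit of > 100000 nM in this assay, at which 4 of the 4 values shown sit.

The compounds shown leave open whether any chain on the shared core gives binding strong enough to put a number on, and how these four truly compare.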